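Working notes: acetamido addition on the outer aromatic ring

A few compounds are considered here, and "the series" means these few. Any claim that something is new, unique, unknown or untested is made for them only; others in the source may bear on it.

Measured compounds:
compound 1, `CCOC(=O)c1cnc2ccc(-c3ccccc3)cc2c1`, in a functional assay on RD cells (Homo sapiens) for inhibition, read by luminescence and ATP content, with a stated time of 72 h; a lower number here means that less compound is tolerated, a higher number that more compound is tolerated: > 7400 nM, a limit of the assay
compound 2, `CCc1nc(-c2cnc3ccc(-c4ccc(C)cc4)cc3c2)no1`, in this assay: > 7400 nM, a limit of the assay
compound 3, `CCc1nc(-c2cnc3ccc(-c4ccccc4)cc3c2)no1`, in this assay: > 7400 nM, a limit of the assay

Compound 3 stands at the limit of this assay, and so do the two other measured compounds; the limit of > 7400 nM in this assay, at which 3 of the 3 values shown sit, sums up that every value shown is a limit and not a number. The step that the two limits leave unreadable from compound 1 to compound 3 is unreadable, and the step that the two limits leave unreadable from compound 2 to compound 3 is unreadable as well; neither gives a size or a direction.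

Compound 4, `CCc1nc(-c2cnc3ccc(-c4ccc(NC(C)=O)cc4)cc3c2)no1`, differs from compound 3 by acetamido in place of hydrogen on an aromatic carbon. Going by the values given here, no measured step reports a size for any change on this ring, so nothing measured bears on the new change beyond the fact that all three values sit at the limit. The step that the limit leaves unreadable from compound 3 to compound 4 is therefore expected to be none beyond the scatter. Compound 4 is expected to sit again at the limit of this assay. Compound 4 is estimated at 9000 nM, with a range from 3000 nM to 30000 nM.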

Compound 4, half-maximal cytotoxic concentration: > 7400 nM
Compound 4 ended at the assay's limit (the forecaster's own chance of this, stated with the estimate: 75%); the middle value lies beyond the limit too.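

Neither step to compound 4, from compound 3 or from compound 2, can be read in this assay, since every value is a limit of the assay: the limit of > 7400 nM in this assay, at which 4 of the 4 values shown sit.

The compounds shown leave open the size and direction of the acetamido change, and how far beyond the limit any of the four compounds lies.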